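Aryl-for-cycloalkyl exchange on the guanidine side chain

The compounds below may be only part of what the source reports. "The series", "measured", "known", "first", "only" and "open" are said of these compounds alone.

Measured so far in a functional assay on membranes from Sf9 cells for agonist activity at histamine H2 receptor (Homo sapiens), read by scintillation counting and GTPgammaS binding, with a stated time of 90 min; a lower number here means a smaller maximal response, a higher number a larger maximal response:
- compound 1 `Cc1nc(N)sc1CCCN/C(N)=N/C(=O)NCC(C)CCc1ccccc1` gives 0.69
- compound 2 `CCCNC(=O)/N=C(\N)NCCCc1sc(N)nc1C` gives 0.79
- compound 3 `Cc1nc(N)sc1CCCN/C(N)=N/C(=O)NCC(C)C1CCCCC1` gives 0.65

Compound 3 stands lowest of the three in this assay. Its nearest neighbour is compound 1, and the step a number 0.040 lower from compound 1 to compound 3 (within the scatter) lies within the scatter; the step from compound 2 is the larger one, since a number 0.14 lower from compound 2 to compound 3 (beyond the scatter) reaches beyond the scatter, though only modestly. The remaining step, a number 0.10 higher from compound 1 to compound 2 (within the scatter), also stays within the scatter.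

Compound 4 `Cc1ccc(CC(C)CNC(=O)/N=C(\N)NCCCc2sc(N)nc2C)cc1` is now the next structure to measure. Relative to compound 3 it carries 4-methylbenzyl in place of cyclohexyl on a saturated chain carbon bound to two saturated chain carbons. The step that bears most directly on this change is a number 0.040 lower from compound 1 to compound 3 (within the scatter), where an aromatic-bearing chain gave way to cyclohexyl with no movement beyond the scatter; the reverse direction, aromatic group back in place of cyclohexyl, would therefore be expected to move little. The step a number 0.14 lower from compound 2 to compound 3 (beyond the scatter) shows that the bare hydrogen sits higher than cyclohexyl, but compound 4 does not return to hydrogen. On this basis the expected step a number 0.050 higher from compound 3 to compound 4 (within the scatter) is small, within the scatter, leaning slightly upward. Compound 4 is thus estimated at 0.7 in this assay, with a range from 0.58 to 0.82.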

Compound 4, intrinsic activity: the largest response reached, as a fraction of the reference agonist's: 0.68
Estimate against measurement, compound 4: 0.020 above, within the range that was stated.
By their numbers in this assay, from the lowest: compounds 3, 4, 1 and 2 (each within the scatter of the next, the first and the last beyond it).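

In this assay, the direct exchange of cyclohexyl for 4-methylbenzyl gives a number 0.030 higher from compound 3 to compound 4 (within the scatter), so at this saturated chain carbon the non-aromatic ring and the aromatic ring carrying a methyl group cannot be told apart by intrinsic activity. The two aromatic side chains also stay together, with a number 0.010 lower from compound 1 to compound 4 (within the scatter), which shows that this second aromatic variant keeps the response in the same range as the first. The comparison with the unbranched side chain gives a number 0.11 lower from compound 2 to compound 4 (beyond the scatter), so compound 4 joins compound 3 in separating from compound 2, but compound 1 goes against any clean split between hydrogen and the larger groups, since its step is a number 0.10 higher from compound 1 to compound 2 (within the scatter).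

From the compounds shown here alone, it remains open whether a ring carrying a hydroxyl group or an amine in place of the methyl group, or a single methyl group in place of the whole ring-bearing substituent, would stay in this same range. Nothing among the data available accounts for how closely the cyclohexyl and aromatic groups agree here.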